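Amide Aryl Variation on a Shared Core

A few compounds are considered here, and "the series" means these few. Any claim that something is new, unique, unknown or untested is made for them only; others in the source may bear on it.

Measured compounds:
Compound 1 `CCOC(=O)c1sc(-c2cccc(NC(=O)c3ccc(C(F)(F)F)cc3)c2)nc1Nc1ccc(N2CCN(C)CC2)cc1` — in a functional assay on Raji cells (Homo sapiens) for antiproliferative activity, read by CCK-8 assay, with a stated time of 72 h (on this read-out higher numbers stand for weaker inhibition and lower numbers for stronger inhibition), compound 1 gives "not determined" (no result reported), that is, no result reported.
Compound 2 `CCOC(=O)c1sc(-c2cccc(NC(=O)c3ccc(F)cc3)c2)nc1Nc1ccc(N2CCN(C)CC2)cc1` — in this assay compound 2 gives "not determined" (no result reported), again no result reported.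
Compound 3 `CCOC(=O)c1sc(-c2cccc(NC(=O)c3cccc(F)c3)c2)nc1Nc1ccc(N2CCN(C)CC2)cc1` — compound 3 gives 21200 nM in this assay.

Compound 1 stands nowhere on the numbers shown: it has no value of its own, and compound 2 likewise has none, so the only number in this set belongs to compound 3. Compound 4 `CCOC(=O)c1sc(-c2cccc(NC(=O)c3ccccc3F)c2)nc1Nc1ccc(N2CCN(C)CC2)cc1` is reached from compound 1 by a single change, (2-fluorophenyl in place of 4-(trifluoromethyl)phenyl on a carbonyl carbon). Among the measured compounds shown here, no step between two measured compounds is available to calibrate that change, and since compound 1 itself carries no number, no direction can be read off for the move from compound 1 to compound 4; nothing in the data supports a shift beyond the scatter in either sense. For the measured compounds named here, the one anchor is compound 3, whose value of 21200 nM shows weak inhibition for a close relative that also bears a single fluorine on the amide aryl ring. Compound 4 is therefore expected to land in the same weak region, estimated at 20000 nM with a range from 6000 nM to 60000 nM in this assay, and a fair chance that only a limit rather than a number is reported.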

Compound 4, half-maximal inhibitory concentration: 9270 nM
Compound 4: middle estimate off by 2.2-fold (0.33 log units), on the high side, within the range that was stated.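

Read in this assay, this pair gives a 2.3-fold lower number from compound 3 to compound 4 (0.36 log units; beyond the scatter), with 2-fluorophenyl in place of 3-fluorophenyl on a carbonyl carbon whose other neighbour is an amide-type nitrogen. It shows what compound 3 alone could not: with the shared core held constant, exchanging one fluorinated aryl group for the other changes the read-out by more than the usual scatter, although compound 4 at 9270 nM still stands for weak inhibition. Nothing available explains why the number changes between these two compounds.

Steps involving compound 1 or compound 2 cannot be read, since neither compound has a reported number, so the standing of 4-(trifluoromethyl)phenyl against 2-fluorophenyl remains unresolved. The compounds shown also leave open whether the lower number in compound 4 would persist with a chlorine atom or a methoxy group on the phenyl ring in place of the fluorine, or with an amine or a carboxylic acid attached there.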